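Unmasking Two Hydroxyls on a Stilbene Arm

The source may hold more compounds than are shown below. What is called first, only, known or untested is meant among the compounds shown, and "the series" means these compounds.

Compound 1 `COc1cc(/C=C/c2ccc(C3=C(c4ccc(O)cc4)C4CC(S(=O)(=O)Oc5ccc(Br)cc5)C3O4)cc2)cc(OC)c1` carries a 3,5-dimethoxyphenyl group on its stilbene arm. In a functional assay on MCF7 cells (Homo sapiens) for antiproliferative activity, read by MTT assay, with a stated time of 72 h (on this read-out lower numbers stand for stronger inhibition and higher numbers for weaker inhibition), compound 1 reaches only a limit of the assay, > 100000 nM. Compound 2 `O=S(=O)(Oc1ccc(Br)cc1)C1CC2OC1C(c1ccc(/C=C/c3cc(O)cc(O)c3)cc1)=C2c1ccc(O)cc1` differs from compound 1 by 3,5-dihydroxyphenyl in place of 3,5-dimethoxyphenyl on a double-bonded chain carbon bound to a double-bonded chain carbon. This change gave an at least 5.9-fold lower number from compound 1 to compound 2 (0.77 log units; beyond the scatter), and the size is known only as a bound because of the limit of > 100000 nM in this assay, at which 1 of the 3 values shown sits. In this assay compound 2 gives 16900 nM. Compound 3 `COc1cc(/C=C/c2ccc(OS(=O)(=O)C3CC4OC3C(c3ccc(O)cc3)=C4c3ccc(O)cc3)cc2)cc(OC)c1` keeps the 3,5-dimethoxyphenyl group, but the difference between its core and the core of compound 1 is not broken down here. In this assay compound 3 gives 3700 nM, the lower of the two numbers. Compound 4 `O=S(=O)(Oc1ccc(/C=C/c2cc(O)cc(O)c2)cc1)C1CC2OC1C(c1ccc(O)cc1)=C2c1ccc(O)cc1` differs from compound 3 by the same change, (3,5-dihydroxyphenyl in place of 3,5-dimethoxyphenyl on a double-bonded chain carbon bound to a double-bonded chain carbon). A comparable step is expected, a 4.1-fold lower number from compound 3 to compound 4 (0.61 log units; beyond the scatter), resting on an at least 5.9-fold lower number from compound 1 to compound 2 (0.77 log units; beyond the scatter). Compound 4 is therefore estimated at 900 nM, likely between 200 nM and 4000 nM.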

Compound 4, half-maximal inhibitory concentration: 10500 nM
Compound 4: the middle estimate sits 12-fold (1.07 log units) below what was measured, outside the stated range (above it).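

In this assay the same swap, 3,5-dihydroxyphenyl in place of 3,5-dimethoxyphenyl, gave a 2.8-fold higher number from compound 3 to compound 4 (0.45 log units; beyond the scatter) and so ran the opposite way to the step on the core of compound 1. The two steps differ: the same change on two cores in this assay, an at least 5.9-fold lower number (0.77 log units; beyond the scatter) from compound 1 to compound 2 and a 2.8-fold higher number (0.45 log units; beyond the scatter) from compound 3 to compound 4, at least 16-fold (1.22 log units) apart, beyond the scatter of two such steps. The size and even the direction of this change therefore did not carry over between these two cores, although two cores cannot show what decides the outcome, and the earlier step is known only as a bound: the limit of > 100000 nM in this assay, at which 1 of the 4 values shown sits.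

Still open, from the compounds shown here alone, is how an amine or a carboxylic acid in place of 3,5-dihydroxyphenyl would behave on each core. Also open, going by these compounds, is whether a third core would follow either step.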